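Compound 4: a Hydroxyphenyl Carbamoylamino Analogue of Compound 1

A few compounds are considered here, and "the series" means these few. Any claim that something is new, unique, unknown or untested is made for them only; others in the source may bear on it.

Compound 1 `COc1cc(NC(C)CCCNC(=O)Nc2cccc(F)c2)c2ncccc2c1` was tested in a functional assay on NCI-H460 cells (Homo sapiens) for inhibition, read by MTT assay, with a stated time of 72 h (a lower number here means a stronger inhibitor, a higher number a weaker inhibitor), where compound 1 gives 24000 nM. Among the three measured compounds it holds the second highest number: compound 2 `COc1cc(NC(C)CCCNC(=O)NNC(=O)Nc2ccc(C(F)(F)F)cc2)c2ncccc2c1` gives 12000 nM, a value within the scatter of compound 1, while compound 3 `COc1cc(NC(C)CCCNC(=O)NNC(=O)Nc2cccc(F)c2)c2ncccc2c1` gives 50000 nM. Compound 4 `COc1cc(NC(C)CCCNC(=O)NNC(=O)Nc2ccc(O)cc2)c2ncccc2c1` has not yet been measured. It differs from compound 1 in one place: ((4-hydroxyphenyl)carbamoyl)amino in place of 3-fluorophenyl on an amide-type nitrogen. Among the compounds with values here, two measured steps bear on this change. The first inserts the same carbamoylamino link while keeping the 3-fluorophenyl, and it gave a 2.1-fold higher number from compound 1 to compound 3 (0.32 log units; beyond the scatter). The second exchanges the aryl group on that extended chain, and it gave a 4.2-fold higher number from compound 2 to compound 3 (0.62 log units; beyond the scatter), showing that the aryl substituent on the longer chain shifts the number by a modest amount. Within the data shown here, no measured compound carries a hydroxy group, so the effect of 4-hydroxyphenyl cannot be read directly from these three compounds. The hydroxyphenyl variant is expected to land between the numbers of compound 2 and compound 3. The expected step is therefore a 1.3-fold higher number from compound 1 to compound 4 (0.10 log units; within the scatter), not clearly beyond the scatter. Compound 4 is estimated at 30000 nM, within a range of 10000 nM to 90000 nM.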

Compound 4, half-maximal inhibitory concentration: > 100000 nM
Compound 4 gave a limit, no number; the forecaster's own chance of this, stated with the estimate: 10%; at least 3.3-fold (0.52 log units) between middle value and limit.
By their numbers in this assay, from the lowest: compounds 2 and 1 (each within the scatter of the next); then compound 3. At a limit, above all of these: compound 4.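

In this assay, within the data shown here, compound 4 gives > 100000 nM, a limit of the assay and not a number, and no other compound shown sits there: the limit of > 100000 nM in this assay, at which 1 of the 4 values shown sits. On the extended chain, the substituent on the aromatic ring now proves to matter more than the earlier aryl exchange showed, since the change to hydroxy gives an at least 8.3-fold higher number from compound 2 to compound 4 (0.92 log units; beyond the scatter) and the whole replacement on the amide-type nitrogen gives an at least 4.1-fold higher number from compound 1 to compound 4 (0.61 log units; beyond the scatter), so this position tolerates 4-hydroxyphenyl poorly on that chain compared with 4-(trifluoromethyl)phenyl. The exchange of 3-fluorophenyl for 4-hydroxyphenyl is less firmly settled, as it gives an at least 2.0-fold higher number from compound 3 to compound 4 (0.30 log units; that floor lies within the scatter) and so does not by itself separate these two aryl groups.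

Going by these compounds, the true size of all three steps stays open, as each rests on a limit and gives only a floor. Also open, on these data alone, is whether a methoxy group or an amine at the place of the hydroxy would keep the number near that of compound 2, and whether 4-hydroxyphenyl directly on the shorter link of compound 1 would behave as it does on the extended chain.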